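A shifted double bond on the carbonyl of compound 1

The compounds below may be only part of what the source reports. "The series", "measured", "known", "first", "only" and "open" are said of these compounds alone.

Compound 1 `C=C(C)C(=O)N(Cc1ccc(OC)c(O)c1)c1cc(OC)c(OC)c(OC)c1` holds the lowest of the two numbers in a functional assay on MGC-803 cells (Homo sapiens) for inhibition, read by MTT assay, with a stated time of 48 h (on this read-out higher numbers stand for weaker inhibition and lower numbers for stronger inhibition), where compound 1 gives 390 nM. Compound 3 `COc1ccc(CNc2cc(OC)c(OC)c(OC)c2)cc1Cl` is its nearest neighbour; in this assay compound 3 gives 46200 nM, a gap far beyond the usual scatter. Compound 2 `COc1cc(NCc2ccccc2)cc(OC)c1OC` stands apart: in this assay compound 2 shows > 80000 nM, which is a limit of the assay and not a number, namely (the limit of > 80000 nM in this assay, at which 1 of the 3 values shown sits).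

Compound 4 `C/C=C/C(=O)N(Cc1ccc(OC)c(O)c1)c1cc(OC)c(OC)c(OC)c1` is built from compound 1 by a single rearrangement: prop-1-en-1-yl in place of 1-methylethenyl on a carbonyl carbon. The two compounds share every other atom, and the change keeps one double bond outside aromatic rings on the carbonyl carbon whose other neighbour is the amide-type nitrogen. For the measured compounds named here, no measured pair in this set tests such a move, so the expectation rests on compound 1 alone. The step from compound 1 to compound 4 is expected to be small, a 1.5-fold higher number from compound 1 to compound 4 (0.19 log units; within the scatter), at most a modest weakening. Compound 4 is therefore estimated at 600 nM, with a likely range from 200 nM to 2500 nM.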

Compound 4, half-maximal inhibitory concentration: 27 nM
Estimate against measurement, compound 4: 22-fold (1.35 log units) above, and the stated range ends above it.
By their numbers in this assay, from the lowest: compound 4; then compound 1; then compound 3. At a limit, above all of these: compound 2.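

For the compounds shown here, until this result, no pair in the set spoke to the group on the carbonyl carbon whose other neighbour is the amide-type nitrogen. In this assay, replacing 1-methylethenyl with prop-1-en-1-yl at this place gives a 14-fold lower number from compound 1 to compound 4 (1.16 log units; beyond the scatter) and shows that the read-out is highly sensitive to how these atoms are joined, even though compound 1 and compound 4 have the same atoms and each keeps one double bond outside aromatic rings on this carbon. No measurement shown here bears on why the step is so large.

As far as these compounds go, whether the double bond itself is needed remains open, as propyl at this place would test it. So does the reach of the trend along the chain, which but-1-en-1-yl or a longer chain would test.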